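The source may hold more compounds than are shown below. What is called first, only, known or untested is meant among the compounds shown, and "the series" means these compounds.

The three measured compounds share one core and differ only at two aromatic positions. Compound 1 `CC1=NNC(=O)C1C(c1c(-c2ccccc2)[nH]c2ccc(C)cc12)c1c(-c2ccccc2)[nH]c2ccc(C)cc12` is tested in a functional assay on HEp-2 cells (Homo sapiens) for cytotoxicity, read by MTT assay; a higher number here means a weaker inhibitor, a lower number a stronger inhibitor. In this assay compound 1 gives > 100000 nM, which is a limit of the assay and not a number. Compound 2 `CC1=NNC(=O)C1C(c1c(-c2ccccc2)[nH]c2ccccc12)c1c(-c2ccccc2)[nH]c2ccc(C)cc12` gives > 100000 nM in this assay, again a limit. The step that the two limits leave unreadable from compound 1 to compound 2 therefore cannot be read. Within the data shown here, compound 3 `CC1=NNC(=O)C1C(c1c[nH]c2ccccc12)c1c(-c2ccccc2)[nH]c2ccc(C)cc12` gives 3200 nM in this assay, the only number among the three. The other two values sit at the limit of > 100000 nM in this assay, at which 2 of the 3 values shown sit. The step of an at least 31-fold lower number from compound 2 to compound 3 (1.49 log units; beyond the scatter) is large.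

Compound 4 `COc1ccc2[nH]c(-c3ccccc3)c(C(c3c[nH]c4ccccc34)C3C(=O)NN=C3C)c2c1` differs from compound 3 by methoxy in place of methyl on an aromatic carbon. Neither measured step bears directly on this change: a step that the two limits leave unreadable from compound 1 to compound 2 is unreadable between two limits, and an at least 31-fold lower number from compound 2 to compound 3 (1.49 log units; beyond the scatter) concerns a different group. In this assay compound 4 is therefore expected to show a step of no change at the digits printed from compound 3 to compound 4 (within the scatter), not beyond the scatter. The estimate for compound 4 is 3200 nM, with a range from 1200 nM to 9000 nM.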

Compound 4, half-maximal inhibitory concentration: 5300 nM
Compound 4: middle estimate off by 1.7-fold (0.22 log units), on the low side; the measured number falls inside the stated range.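

Among these compounds, the first readable step at this position is a 1.7-fold higher number from compound 3 to compound 4 (0.22 log units; within the scatter) in this assay, and it comes with methoxy in place of methyl on an aromatic carbon of a six-membered aromatic ring of carbon only. The earlier compounds shown here gave no reading of a change at this place, and here methoxy, with 2 heavy atoms and 1 hydrogen-bond acceptor, reads alike with methyl, with 1 heavy atom and 0 hydrogen-bond acceptors, so the low number of compound 3 survives this swap. Nothing given here offers a cause for this outcome.

The compounds shown leave open what an amine, a carboxylic acid or a longer chain would give on this aromatic carbon. They also leave open whether methyl and methoxy would read alike on the core of compound 2, with its added phenyl.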